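A Second Fluorine on the Phenylethyl Side Chain

This account rests on a few compounds, and the source may have more. Where it says the series, first, only, none or still open, it means among the compounds named here.

Measured in an assay on HEK293 cells for inhibition of SCN8A/SCN1B (Homo sapiens), read by patch clamp, with a stated time of 20 min; on this read-out higher numbers stand for weaker inhibition and lower numbers for stronger inhibition:
compound 1, `CC(Nc1ccc(S(=O)(=O)Nc2nccs2)cc1Cl)c1ccccc1`: 100 nM
compound 2, `C[C@H](Nc1ccc(S(=O)(=O)Nc2nccs2)cc1Cl)c1ccccc1`: 130 nM
compound 3, `C[C@H](Nc1cc(F)c(S(=O)(=O)Nc2nccs2)cc1Cl)c1ccccc1`: 20 nM

Compound 3 stands lowest of the three numbers, and its distance to each of compound 1 and compound 2 lies beyond the scatter. Compound 4 is `C[C@H](Nc1cc(F)c(S(=O)(=O)Nc2nccs2)cc1Cl)c1ccc(F)cc1`; it differs from compound 3 by fluoro in place of hydrogen on an aromatic carbon, the fluorine sitting on the six-membered carbon ring of the 1-phenylethyl group, para to a large group. Two measured steps exist. The step of a 1.3-fold higher number from compound 1 to compound 2 (0.11 log units; within the scatter) changes only how the stereocentre is drawn, and the fact that one of compounds 1 and 2 is drawn with a defined configuration and the other without, at the place where they differ is the sole distinction, so it says nothing about adding a fluorine. The step of a 6.5-fold lower number from compound 2 to compound 3 (0.81 log units; beyond the scatter) is the same kind of exchange, though on the core ring rather than the side-chain ring, and it lowered the number. A smaller effect, or none beyond the scatter, is expected here, since the ring is different. Compound 4 is therefore expected to give about 15 nM, between 5 nM and 45 nM, which would mean a 1.3-fold lower number from compound 3 to compound 4 (0.12 log units; within the scatter).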

Compound 4, half-maximal inhibitory concentration: 230 nM
For compound 4 the middle estimate is 15-fold (1.19 log units) below the measured one; measured number above the stated range.
By their numbers in this assay, from the lowest: compound 3; then compounds 1, 2 and 4 (each within the scatter of the next, the first and the last beyond it).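

In this assay putting fluoro on the ring of the 1-phenylethyl group gives a 12-fold higher number from compound 3 to compound 4 (1.06 log units; beyond the scatter) and so weakens inhibition, while the same exchange on the core ring gave a 6.5-fold lower number from compound 2 to compound 3 (0.81 log units; beyond the scatter) and strengthened it. Across these two steps, then, one exchange of hydrogen for fluoro moves the number in opposite directions depending on the ring that carries it, and the place para to a large group on the side-chain ring is where it costs inhibition. No measurement shown bears on the reason for this reversal.

On these data alone, it stays open whether the loss is particular to fluoro or would also follow a chloro, methyl or methoxy group at the same place. Whether fluoro on another carbon of that ring behaves in the same way is open too.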